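The compounds below may be only part of what the source reports. "The series", "measured", "known", "first", "only" and "open" are said of these compounds alone.

In an ADME assay on HeLa cells (Homo sapiens) for cytotoxicity, read by MTT assay, with a stated time of 2 days (on this read-out higher numbers stand for lower toxicity in this test and lower numbers for higher toxicity in this test), compound 1 `CCOC(=O)c1sc2cc(Oc3ccnc(C(=O)NC)c3)ccc2c1CC` gives 16700 nM, compound 2 `CNC(=O)c1cc(Oc2ccc3cc(C(=O)OC)sc3c2)ccn1` gives 68300 nM and compound 3 `CNC(=O)c1cc(Oc2ccc3c(C)c(C(=O)OC)sc3c2)ccn1` gives 15700 nM. Compound 3 and compound 1 lie within the scatter of each other, and the values of both are lower than that of compound 2. Compound 4 `CCNC(=O)c1sc2cc(Oc3ccnc(C(=O)NC)c3)ccc2c1C` differs from compound 3 as follows: ethylamino in place of methoxy on a carbonyl carbon. Among the measured compounds shown here, the only measured step, a 4.4-fold lower number from compound 2 to compound 3 (0.64 log units; beyond the scatter), is modest and concerns methyl in place of hydrogen on an aromatic carbon. For the measured compounds named here, no measured pair covers a change at the carbonyl. No shift beyond the scatter is therefore expected in this assay, in either direction. The estimated step is a 1.3-fold higher number from compound 3 to compound 4 (0.11 log units; within the scatter). For compound 4 the estimated value is 20000 nM, with an expected range of 7000 nM to 60000 nM.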

Compound 4, half-maximal cytotoxic concentration: > 100000 nM
Compound 4 gave a limit, no number; the forecaster's own chance of this, stated with the estimate: 10%; middle value at least 5.0-fold (0.69 log units) from the limit.
By their numbers in this assay, from the lowest: compounds 3 and 1 (each within the scatter of the next); then compound 2. At a limit, above all of these: compound 4.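

The carbonyl substituent matters in this series: with ethylamino in place of methoxy on a carbonyl carbon, this assay shows an at least 6.3-fold higher number from compound 3 to compound 4 (0.80 log units; beyond the scatter). This moves the read-out towards lower toxicity in this test, so the aromatic carbon is not the only place where a single change registers. Compound 4 gives a limit rather than a number: the limit of > 100000 nM in this assay, at which 1 of the 4 values shown sits.

As far as these compounds go, the true size of the step remains open, as does whether it follows from the nitrogen or from the ethyl chain. Methylamino, a plain amino group or a carboxylic acid on the same carbonyl carbon would separate these readings.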